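Ethoxy in place of the pyridinylmethoxy arm

The source may report more compounds than this note shows. Statements on the series, on what has been measured and on what is new or still open speak of the compounds shown alone.

Among the compounds with values here, compound 2 `O=C(O)CCn1c(=O)oc2cc(OCc3ccccn3)c(Cl)cc21` gives 5010 nM in an assay on HEK293 cells for inhibition of kynurenine 3-monooxygenase (Homo sapiens), read by LC-MS, with a stated time of 20 h (a higher number here means a weaker inhibitor, a lower number a stronger inhibitor), the higher of the two numbers measured so far. Compound 1 `C[C@@H](Oc1cc2oc(=O)n(CCC(=O)O)c2cc1Cl)c1cccnn1` gives 631 nM in this assay, and the step of a 7.9-fold higher number from compound 1 to compound 2 (0.90 log units; beyond the scatter) shows how much the number moved when the aromatic ring on the ether oxygen was exchanged. Compound 3 `CCOc1cc2oc(=O)n(CCC(=O)O)c2cc1Cl` has not yet been measured. It differs from compound 2 by methyl in place of pyridin-2-yl on a saturated chain carbon bound to an oxygen on an aromatic ring. Within the data shown here, no measured step removes the ring from this arm altogether, so the only bearing is indirect: the step from compound 1 to compound 2 already shifted the number beyond the scatter on a change confined to that ring. Removal of the whole ring is therefore expected to weaken inhibition further, by a modest margin, with wide uncertainty. Compound 3 is estimated at 12000 nM, range 3000 nM to 50000 nM, an expected step of a 2.4-fold higher number from compound 2 to compound 3 (0.38 log units; beyond the scatter).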

Compound 3, half-maximal inhibitory concentration: 398 nM
For compound 3 the middle estimate is 30-fold (1.48 log units) above the measured one; measured number below the stated range.
By their numbers in this assay, from the lowest: compounds 3 and 1 (each within the scatter of the next); then compound 2.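

In this assay, removing the ring from this arm does not cost inhibition: a 13-fold lower number from compound 2 to compound 3 (1.10 log units; beyond the scatter). The penalty seen with compound 2 therefore belongs to the pyridin-2-yl group as present on this arm, and cannot be read as a general need for an aromatic ring here. The ethoxy arm and the pyridazin-3-yl arm cannot be told apart, with a 1.6-fold lower number from compound 1 to compound 3 (0.20 log units; within the scatter), so an aromatic ring on this arm is not required for a number of this size, and no data at hand explain the loss with pyridin-2-yl.

On these data alone, whether a longer chain such as propyl on the oxygen moves the number beyond the scatter from that of compound 3 remains open. So does whether pyridin-3-yl or pyridin-4-yl on the same arm carries the penalty of pyridin-2-yl.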